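The source may report more compounds than this note shows. Statements on the series, on what has been measured and on what is new or still open speak of the compounds shown alone.

Within the data shown here, compound 1 `O=C(/C=C/c1ccc(OCCCCO[N+](=O)[O-])c(O)c1)OCCCCO[N+](=O)[O-]` is one of two compounds measured so far. In a functional assay on HeLa cells (Homo sapiens) for cytotoxicity, read by resazurin assay, with a stated time of 72 h (a higher number here means a weaker inhibitor, a lower number a stronger inhibitor), compound 1 gives 3930 nM. The other measured compound, compound 2 `COc1cc(/C=C/C(=O)OCc2cccc(OCc3c(-c4ccccc4)no[n+]3[O-])c2)ccc1O`, gives 5640 nM in this assay, a number that lies within the usual scatter of that of compound 1, so the two cannot be told apart on these data. Compound 3 `COc1cc(/C=C/C(=O)OCCCCO[N+](=O)[O-])ccc1OCCCCO[N+](=O)[O-]` has not yet been measured; it differs from compound 1 by methyl in place of hydrogen on an oxygen on an aromatic ring. Among the measured compounds shown here, no measured pair shows what this small change does, so no step beyond the scatter is expected in either direction. Compound 3 is therefore expected to give about 4000 nM, between 1600 nM and 10000 nM. The step this estimate means, a 1.0-fold higher number from compound 1 to compound 3 (0.01 log units; within the scatter), is expected to stay within the scatter.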

Compound 3, half-maximal inhibitory concentration: 740 nM
The estimate for compound 3 lay 5.4-fold (0.73 log units) above the measured number, outside the stated range (below it).
By their numbers in this assay, from the lowest: compound 3; then compounds 1 and 2 (each within the scatter of the next).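

In this assay the change from hydroxy to methoxy on this oxygen on an aromatic ring gives a 5.3-fold lower number from compound 1 to compound 3 (0.73 log units; beyond the scatter). A single added carbon at this position is thus enough to move the number beyond the scatter, which the two earlier compounds could not show, as they differ in more than one place. Nothing available explains this step. On these data alone, whether an ethyl group or a longer chain on this oxygen would lower the number further stays open, as does what an amine in place of the methoxy would do.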